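The source may hold more compounds than are shown below. What is called first, only, known or untested is meant among the compounds shown, and "the series" means these compounds.

Compound 1 `CN1CCN(CCCn2c(N)c(-c3nc4ccccc4[nH]3)c3nc(C#N)c(C#N)nc32)CC1` gives 750 nM in a functional assay on HL-60 cells (Homo sapiens) for antiproliferative activity, read by MTT assay, with a stated time of 48 h; a lower number here means a stronger inhibitor, a higher number a weaker inhibitor.
Compound 2 `N#Cc1nc2c(-c3nc4ccccc4[nH]3)c(N)n(CCCO)c2nc1C#N` gives > 50000 nM in this assay.

For compound 2 that figure is a limit of this assay, not a number: the limit of > 50000 nM in this assay, at which 1 of the 2 values shown sits. Compound 3 `N#Cc1nc2c(-c3nc4ccccc4[nH]3)c(N)n(CCCNc3ccccc3)c2nc1C#N` differs from compound 2 by anilino in place of hydroxy on a saturated chain carbon, three bonds along the chain from an aromatic nitrogen. Among the compounds with values here, the only measured step at this position, an at least 66-fold higher number from compound 1 to compound 2 (1.82 log units; beyond the scatter), shows that replacing the nitrogen-bearing chain end with hydroxy weakened inhibition strongly. Bringing a nitrogen-bearing group back is expected to recover some activity, but anilino is not the group that was lost, so only a moderate improvement is expected: an at least 5.0-fold lower number from compound 2 to compound 3 (0.69 log units; beyond the scatter). Compound 3 is estimated at 10000 nM, within 2000 nM to 50000 nM.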

Compound 3, half-maximal inhibitory concentration: 6920 nM
Compound 3: the middle estimate sits 1.4-fold (0.16 log units) above what was measured; low and high end bracket the measured number.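

Replacing hydroxy with anilino gives an at least 7.2-fold lower number from compound 2 to compound 3 (0.85 log units; beyond the scatter), so this chain end can give a measurable value without 4-methylpiperazin-1-yl. Activity is not fully regained, with a 9.2-fold higher number from compound 1 to compound 3 (0.97 log units; beyond the scatter), so at this position a nitrogen-bearing group alone does not match compound 1. Compound 2 stands at a limit, not a number: the limit of > 50000 nM in this assay, at which 1 of the 3 values shown sits.

The compounds shown leave open whether a simple dimethylamino group or a morpholine ring at the chain end would match 4-methylpiperazin-1-yl. They also leave open how a shorter or longer chain would behave.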